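Anilinomethyl replaces chlorobenzyl on the amide carbonyl

The compounds below may be only part of what the source reports. "The series", "measured", "known", "first", "only" and "open" are said of these compounds alone.

Measured so far:
Compound 1, `CC(C)C[C@H](N)c1cc(Cl)ccc1N1CCN(C(=O)C(C)Cc2ccc(Cl)cc2)CC1`, gives 67 nM in an assay on HEK293 cells for displacement of a labelled ligand from Melanocortin receptor 4 (Homo sapiens); a lower number here means a stronger inhibitor, a higher number a weaker inhibitor.
Compound 2, `CC(C)C[C@H](N)c1cc(C(F)(F)F)ccc1N1CCN(C(=O)[C@H](C)Cc2ccc(Cl)cc2)CC1`, gives 31 nM in this assay.

Compound 2 has the lowest of the two numbers; its nearest neighbour is compound 1, whose number is higher by a margin beyond the usual scatter. Compound 3, `CC(C)C[C@H](N)c1cc(C(F)(F)F)ccc1N1CCN(C(=O)CNc2ccccc2)CC1`, is not yet measured. It differs from compound 2 in one place: anilinomethyl in place of 1-(4-chlorobenzyl)ethyl on a carbonyl carbon. Going by the values given here, no measured pair shows a change of this kind, so the size of the step rests on judgement alone. The group that enters is smaller and carries a hydrogen-bond donor and acceptor that the leaving group lacks, and the defined stereocentre is lost. The step from compound 2 to compound 3 in this assay is expected to be a 9.7-fold higher number from compound 2 to compound 3 (0.99 log units; beyond the scatter), toward a weaker inhibitor. Compound 3 is therefore estimated to give 300 nM in this assay, within a range from 60 nM to 1500 nM.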

Compound 3, inhibition constant: 3600 nM
Compound 3: middle estimate off by 12-fold (1.08 log units), on the low side; measured number outside the range, above it.
By their numbers in this assay, from the lowest: compound 2; then compound 1; then compound 3.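

In this assay, the substituent on this amide carbonyl proves highly sensitive to change: replacing 1-(4-chlorobenzyl)ethyl with anilinomethyl gives a 120-fold higher number from compound 2 to compound 3 (2.06 log units; beyond the scatter) for this single exchange. Both groups carry a six-membered aromatic ring of carbon only, so in this pair, the presence of such a ring on the carbonyl carbon does not by itself keep the number low. This one step cannot separate the loss of the chlorine and the defined stereocentre from the gain of the nitrogen, and no supporting data explain its size.

As far as these compounds go, it remains open whether a 2-phenylethyl group, an all-carbon chain, would give a number closer to that of compound 2 or compound 3. It is also unknown whether adding a chlorine to the aniline ring would lower the number.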